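Compound 4: phenylsulfonyl on the amine nitrogen

The source may hold more compounds than are shown below. What is called first, only, known or untested is meant among the compounds shown, and "the series" means these compounds.

Measured so far in an ADME assay on HepG2 cells (Homo sapiens) for cytotoxicity (on this read-out higher numbers stand for an effect only at larger amounts of compound and lower numbers for an effect already at smaller amounts), each value a limit:
- compound 1 `Cc1ccc(S(=O)(=O)N[C@@H](CC(=O)NC(C)(C)C)C(=O)NCCNC(=O)c2cccc(O)c2)cc1`: > 11000 nM
- compound 2 `Cc1ccc(S(=O)(=O)N[C@@H](CC(=O)NC(C)(C)C)C(=O)NCCNC(=O)c2cc(Cl)ccc2Cl)cc1`: > 11000 nM
- compound 3 `Cc1ccc(S(=O)(=O)N[C@@H](CC(=O)NC(C)(C)C)C(=O)NCCNC(=O)c2cc(C)ccc2F)cc1`: > 11000 nM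

Compound 3 gives > 11000 nM, which is a limit and not a number. It therefore has no readable place within the series, whose values all sit at the limit of > 11000 nM in this assay, at which 3 of the 3 values shown sit.

The next structure is compound 4 `Cc1ccc(S(=O)(=O)N[C@@H](CC(=O)NC(C)(C)C)C(=O)NCCNS(=O)(=O)c2ccccc2)cc1`. Its difference from compound 3 is a group of 9 heavy atoms (6 carbon, 2 oxygen, 1 sulfur; one six-membered aromatic ring of carbon only) in place of a group of 10 heavy atoms (8 carbon, 1 oxygen, 1 fluorine; one six-membered aromatic ring of carbon only), on an amine nitrogen. Phenylsulfonyl thus enters on an amine nitrogen, in place of the group that compound 3 carries there.

Among the compounds with values here, three measured steps bear on this change, though only indirectly, as each exchanges one aromatic group on a carbonyl carbon for another: a step that the two limits leave unreadable from compound 1 to compound 2, a step that the two limits leave unreadable from compound 1 to compound 3 and a step that the two limits leave unreadable from compound 2 to compound 3. Within the data shown here, none has a readable size, and no measured step replaces the carbonyl itself. The series therefore offers no size or direction to carry over to compound 4, and the expectation is simply that this assay again reports a limit.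

The expected change is a step that the limit leaves unreadable from compound 3 to compound 4, with no readable direction anticipated. For compound 4 the estimated value is 16000 nM, with an expected range from 9000 nM to 30000 nM.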

Compound 4, half-maximal effective concentration: > 11000 nM
Compound 4 gave a limit, no number; the forecaster's own chance of this, stated with the estimate: 90%; the middle value does not contradict the limit.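

In this assay, within the data shown here, compound 4 gives > 11000 nM, which is a limit and not a number, so no step from compound 1, compound 2 or compound 3 to compound 4 can be read. The compounds shown leave open whether phenylsulfonyl and the aryl carbonyl groups on the amine nitrogen differ at all in this assay: the limit of > 11000 nM in this assay, at which 4 of the 4 values shown sit.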